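Cyclopentenone series: swapping dimethoxyphenyl isomers on the core

The source may hold more compounds than are shown below. What is called first, only, known or untested is meant among the compounds shown, and "the series" means these compounds.

Compound 1 `COc1ccc(C2=C(c3cc(OC)c(OC)c(OC)c3)C(=O)CC2O[SiH2]C(C)(C)C)cc1OC` is tested in an ADME assay on MIA PaCa-2 cells (Homo sapiens) for cytotoxicity, read by MTT assay, with a stated time of 72 h; a lower number here means a stronger inhibitor, a higher number a weaker inhibitor. In this assay compound 1 gives only a limit, > 100 ug/mL, not a number. Compound 2 `COc1ccc(C2=C(c3cc(OC)c(OC)c(OC)c3)CC(O)C2=O)cc1[N+](=O)[O-]` likewise reaches only the limit > 100 ug/mL in this assay. Compound 3 `COc1cc(C2=C(c3cc(C)c(OC)c(C)c3)C(O)CC2=O)cc(OC)c1OC` also stops at the limit > 100 ug/mL. For the measured compounds named here, all three values shown therefore sit at the limit of > 100 ug/mL in this assay, at which 3 of the 3 values shown sit, so compound 1 stands nowhere above or below its neighbours; no step between measured compounds is available. Compound 4 `COc1ccc(OC)c(C2=C(c3cc(OC)c(OC)c(OC)c3)C(=O)CC2O[SiH2]C(C)(C)C)c1` is not yet measured; it differs from compound 1 by 2,5-dimethoxyphenyl in place of 3,4-dimethoxyphenyl on a double-bonded ring carbon. Going by the values given here, no measured step supports a shift in either direction, so the expectation is no change beyond the scatter, a number no higher from compound 1 to compound 4 (the limit leaves the size open). Compound 4 is estimated at 100 ug/mL, within 40 ug/mL to 100 ug/mL.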

Compound 4, half-maximal inhibitory concentration: > 100 ug/mL
Compound 4 gave a limit, no number; the forecaster's own chance of this, stated with the estimate: 80%; the middle value sits exactly at the limit.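

Compound 1 and compound 4 both give only a limit, not a number, so no step can be read between them: the limit of > 100 ug/mL in this assay, at which 4 of the 4 values shown sit. The compounds shown leave open whether 2,5-dimethoxyphenyl and 3,4-dimethoxyphenyl differ at all in this assay.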